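From 3-chlorophenyl to (1H-benzimidazol-2-yl)methyl on nitrogen

The source may report more compounds than this note shows. Statements on the series, on what has been measured and on what is new or still open speak of the compounds shown alone.

compound 1 `N#Cc1cc(-c2ccccc2)n(Cc2nc3ccccc3[nH]2)c1N`: 12000 nM
compound 2 `Nc1c(-c2nc3ccccc3[nH]2)cc(-c2ccccc2)n1-c1cccc(Br)c1`: 13500 nM
compound 3 `Nc1c(-c2nc3ccccc3[nH]2)cc(-c2ccccc2)n1-c1cccc(Cl)c1`: 7000 nM

In a functional assay on A549 cells (Homo sapiens) for cytotoxicity, read by resazurin assay, with a stated time of 72 h (a lower number here means a stronger inhibitor, a higher number a weaker inhibitor), compound 3 gives 7000 nM, within the scatter of both compound 1 and compound 2. Compound 4 `Nc1c(-c2nc3ccccc3[nH]2)cc(-c2ccccc2)n1Cc1nc2ccccc2[nH]1` keeps the core of compound 3 but carries (1H-benzimidazol-2-yl)methyl in place of 3-chlorophenyl on an aromatic nitrogen. For the measured compounds named here, the only measured step, a 1.9-fold lower number from compound 2 to compound 3 (0.29 log units; within the scatter), swaps one halogen for another and offers little guidance here. Compound 1, built on a different core, carries the entering group and gives 12000 nM. In this assay the expected step is therefore a 1.1-fold higher number from compound 3 to compound 4 (0.06 log units; within the scatter), none beyond the scatter. For compound 4 the estimated value is 8000 nM, expected between 2500 nM and 25000 nM.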

Compound 4, half-maximal inhibitory concentration: 5100 nM
For compound 4 the middle estimate is 1.6-fold (0.20 log units) above the measured one, and the stated range covers the measured number.
By their numbers in this assay, from the lowest: compounds 4, 3, 1 and 2 (each within the scatter of the next, the first and the last beyond it).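

In this assay, (1H-benzimidazol-2-yl)methyl in place of 3-chlorophenyl on the aromatic nitrogen gives a 1.4-fold lower number from compound 3 to compound 4 (0.14 log units; within the scatter), so the 3-chlorophenyl group is not needed at this position. For the compounds shown here, the same group in place of 3-bromophenyl gives a 2.6-fold lower number from compound 2 to compound 4 (0.42 log units; beyond the scatter), and 1H-benzimidazol-2-yl in place of cyano on the aromatic carbon gives a 2.4-fold lower number from compound 1 to compound 4 (0.37 log units; beyond the scatter); these are the first steps to pass the scatter. Nothing available explains these steps. As far as these compounds go, it remains open whether a plain benzyl group, or an amine on a longer chain, on that nitrogen would move the number further.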